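The compounds below may be only part of what the source reports. "The series", "measured", "known", "first", "only" and "open" are said of these compounds alone.

Working notes on the series. In a functional assay on HeLa S3 cells (Homo sapiens) for cytotoxicity, read by XTT assay, with a stated time of 3 days (on this read-out higher numbers stand for weaker inhibition and lower numbers for stronger inhibition), compound 1 (`OC[C@H]1O[C@@H](n2cc(F)c3c(-c4ccco4)ncnc32)[C@H](O)[C@@H]1O`) reads 8000 nM, compound 2 (`OC[C@H]1O[C@@H](n2cc(F)c3c(-c4cccs4)ncnc32)[C@H](O)[C@@H]1O`) reads 4300 nM and compound 3 (`OC[C@H]1O[C@@H](n2cc(F)c3c(-c4nccs4)ncnc32)[C@H](O)[C@@H]1O`) reads 3100 nM. Compound 1 therefore lies within the scatter of compound 2, with a 1.9-fold lower number from compound 1 to compound 2 (0.27 log units; within the scatter), but not of compound 3, with a 2.6-fold lower number from compound 1 to compound 3 (0.41 log units; beyond the scatter).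

Compound 4 (`OC[C@H]1O[C@@H](n2cc(F)c3c(-c4ccsc4)ncnc32)[C@H](O)[C@@H]1O`) is not yet measured in this assay. It has thiophen-3-yl in place of furan-2-yl on an aromatic carbon of the core of compound 1: thiophen-3-yl in place of furan-2-yl on an aromatic carbon.

Going by the values given here, no measured compound carries thiophen-3-yl, so the nearest guide is the thiophen-2-yl group of compound 2. Replacing that group in compound 2 gave a 1.4-fold lower number from compound 2 to compound 3 (0.14 log units; within the scatter), which also stays small. A lower number than compound 1 is therefore expected, of about the size seen for compound 2, at the edge of the scatter. The expected change is a 1.9-fold lower number from compound 1 to compound 4 (0.28 log units; within the scatter). For compound 4 the estimate is 4200 nM, with an expected range of 2100 nM to 8000 nM.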

Compound 4, half-maximal inhibitory concentration: 210 nM
The estimate for compound 4 lay 20-fold (1.30 log units) above the measured number; measured number below the stated range.
By their numbers in this assay, from the lowest: compound 4; then compounds 3, 2 and 1 (each within the scatter of the next, the first and the last beyond it).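

In this assay, going by these compounds alone, the earlier compounds gave no sign that this position could respond so strongly: thiophen-3-yl gives a 38-fold lower number from compound 1 to compound 4 (1.58 log units; beyond the scatter) and also a 15-fold lower number from compound 3 to compound 4 (1.17 log units; beyond the scatter) for the replacement of 1,3-thiazol-2-yl. The sharpest comparison is between the two thiophenes, where only the ring atom joined to the shared core differs, and this gives a 20-fold lower number from compound 2 to compound 4 (1.31 log units; beyond the scatter), so the presence of a thiophene ring alone does not set the read-out here. No measurement on hand explains this large step.

The compounds shown leave open whether furan-3-yl or phenyl at this position would also give a low number. Going by these compounds, it also remains open whether a methyl group or an amine on the thiophen-3-yl ring would keep the gain.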